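The source may report more compounds than this note shows. Statements on the series, on what has been measured and on what is new or still open speak of the compounds shown alone.

Measured compounds:
compound 1, `CCNC(=O)Nc1ccc(-c2nc3n(Cc4c(F)cccc4F)cc(C(=O)OCC)c(=O)n3c2CN(CC(=O)NCc2cn(CCOCCOCCOCCOCCN=[N+]=[N-])nn2)Cc2ccccc2)cc1`, 832 nM
compound 2, `CCNC(=O)Nc1ccc(-c2nc3n(Cc4c(F)cccc4F)cc(C(=O)NCc4cn(CCOCCOCCOCCN=[N+]=[N-])nn4)c(=O)n3c2CN(C)Cc2ccccc2)cc1`, < 10000 nM
compound 3, `CCNC(=O)Nc1ccc(-c2nc3n(Cc4c(F)cccc4F)cc(C(=O)OCC)c(=O)n3c2CN(CC(=O)NCc2cn(CCOCCOCCOCCN=[N+]=[N-])nn2)Cc2ccccc2)cc1`, 724 nM

In a functional assay on CHO cells for antagonist activity at Gonadotropin-releasing hormone receptor (Homo sapiens), read by a luciferase reporter, with a stated time of 30 min (on this read-out higher numbers stand for weaker inhibition and lower numbers for stronger inhibition), compound 1 gives 832 nM and compound 3 gives 724 nM, two values that lie within the usual scatter of each other. Compound 2 stands apart: in this assay compound 2 gives only a limit, < 10000 nM, so no number is known for it. This is the limit of < 10000 nM in this assay, at which 1 of the 3 values shown sits, and it leaves the true potency of compound 2 open.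

Compound 4, `CCNC(=O)Nc1ccc(-c2nc3n(Cc4c(F)cccc4F)cc(C(=O)NCc4cn(CCOCCN=[N+]=[N-])nn4)c(=O)n3c2CN(C)Cc2ccccc2)cc1`, differs from compound 2 in one place: azido in place of 2-(2-azidoethoxy)ethoxy on a saturated chain carbon, two bonds along the chain from an oxygen on a saturated carbon. The change shortens a tether on the outer edge of the molecule and touches no ring of the shared core. Among the measured compounds shown here, no measured pair shows such a tether change on its own, so no step beyond the scatter is expected; the step that the limit leaves unreadable from compound 2 to compound 4 is estimated to be small. Compound 4 is expected to give about 3000 nM in this assay, in the range from 600 nM to 10000 nM.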

Compound 4, half-maximal inhibitory concentration: < 10000 nM
Compound 4: only a limit was reported; the forecaster's own chance of this, stated with the estimate: 35%; the middle value lies beyond the limit too.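

Among the compounds shown here, compound 2 and compound 4 are each reported only as a limit, so no step between them can be read: the limit of < 10000 nM in this assay, at which 2 of the 4 values shown sit. The compounds shown leave open whether azido in place of 2-(2-azidoethoxy)ethoxy changes potency at all.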